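Swapping the aryl amide of compound 3 for a trimethylpyrrole

A few compounds are considered here, and "the series" means these few. Any claim that something is new, unique, unknown or untested is made for them only; others in the source may bear on it.

Three compounds sharing one core differ only in the aromatic group attached to the carbonyl carbon of the outer amide. Compound 1 `O=C(Nc1ccc2nc(NC(=O)C3CCCCC3)sc2c1)c1cccc(F)c1` carries a 3-fluorophenyl there and in a functional assay on WI-38 VA13 cells (Homo sapiens) for cytotoxicity (on this read-out lower numbers stand for an effect already at smaller amounts and higher numbers for an effect only at larger amounts of compound), compound 1 gives 0.64 ug/mL. Compound 2 `O=C(Nc1ccc2nc(NC(=O)C3CCCCC3)sc2c1)c1ccc(Cl)cc1Cl` carries a 2,4-dichlorophenyl; in this assay compound 2 reaches only the limit > 4 ug/mL, which is a limit and not a number (the limit of > 4 ug/mL in this assay, at which 1 of the 3 values shown sits). Compound 3 `O=C(Nc1ccc2nc(NC(=O)C3CCCCC3)sc2c1)c1cccnc1Cl` carries a 2-chloropyridin-3-yl and gives 0.075 ug/mL in this assay, the lowest number among these compounds. The steps show how strongly this position acts: an at least 6.2-fold higher number from compound 1 to compound 2 (0.79 log units; beyond the scatter), an 8.5-fold lower number from compound 1 to compound 3 (0.93 log units; beyond the scatter) and an at least 53-fold lower number from compound 2 to compound 3 (1.72 log units; beyond the scatter).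

Compound 4 `Cc1cc(C(=O)Nc2ccc3nc(NC(=O)C4CCCCC4)sc3c2)c(C)n1C` is not yet measured. It differs from compound 3 as follows: 1,2,5-trimethyl-1H-pyrrol-3-yl in place of 2-chloropyridin-3-yl on a carbonyl carbon. The measured steps at this position are modest to large, so a change beyond the scatter is expected, and since compound 3 already sits lowest, the estimate for compound 4 leans towards a higher number, a 6.7-fold higher number from compound 3 to compound 4 (0.82 log units; beyond the scatter). For compound 4 the expected result in this assay is 0.5 ug/mL, within a range from 0.1 ug/mL to 4 ug/mL.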

Compound 4, half-maximal effective concentration: > 6.2 ug/mL
Compound 4 was reported as a limit (the forecaster's own chance of this, stated with the estimate: 20%); middle value at least 12-fold (1.09 log units) from the limit.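

In this assay the change to 1,2,5-trimethyl-1H-pyrrol-3-yl gives an at least 82-fold higher number from compound 3 to compound 4 (1.91 log units; beyond the scatter) and also an at least 9.6-fold higher number from compound 1 to compound 4 (0.98 log units; beyond the scatter). Compound 4 is reported only as a limit: the limit of > 6.2 ug/mL in this assay, at which 1 of the 4 values shown sits. The leaving and entering rings each hold one hetero atom and have the same hydrogen-bond donor and acceptor counts, so those counts alone do not preserve the low number of compound 3, and compound 4 is the first compound shown here with no halogen on this aromatic group.

Compound 2 and compound 4 are both limits, so the step between them cannot be read. Open questions are whether a pyrrole without the three methyl groups, a pyridine without the chlorine, or a piperidine on this carbonyl carbon would give a low number.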